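The compounds below may be only part of what the source reports. "The series", "measured", "known", "first", "only" and "open" are said of these compounds alone.

In a functional assay on PC-9 cells (Homo sapiens) for inhibition, read by MTT assay, with a stated time of 72 h (a higher number here means a weaker inhibitor, a lower number a stronger inhibitor), compound 1 `Cc1cc(Nc2cc(-c3ccccc3)[nH]n2)n2nc(SCCCc3ccccc3)nc2n1` gives 5030 nM and compound 2 `Cc1cc(Nc2cc(-c3ccccc3)[nH]n2)n2nc(SCc3nc4ccccc4[nH]3)nc2n1` gives 4840 nM, so compound 2 stands level with compound 1. Going by the values given here, the only measured step, a 1.0-fold lower number from compound 1 to compound 2 (0.02 log units; within the scatter), lies within the scatter, and it exchanges one group for another on the sulfur-bound chain without removing the chain. Compound 3 `Cc1cc(Nc2cc(-c3ccccc3)[nH]n2)n2ncnc2n1` differs from compound 2 by hydrogen in place of ((1H-benzimidazol-2-yl)methyl)sulfanyl on an aromatic carbon, with hydrogen in place of ((1H-benzimidazol-2-yl)methyl)sulfanyl on an aromatic carbon. Among the compounds with values here, no measured step tests such a removal, so only a modest rise in the number is expected, an estimated 2.1-fold higher number from compound 2 to compound 3 (0.32 log units; beyond the scatter). For compound 3 the estimated value is 10000 nM, with an expected range of 3000 nM to 35000 nM.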

Compound 3, half-maximal inhibitory concentration: > 50000 nM
Compound 3: no number, only a limit (the forecaster's own chance of this, stated with the estimate: 25%); middle value at least 5.0-fold (0.69 log units) from the limit.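

On the aromatic carbon between two ring nitrogen atoms, a sulfur-linked substituent is needed for measurable inhibition in this assay: hydrogen in place of ((1H-benzimidazol-2-yl)methyl)sulfanyl gives an at least 10-fold higher number from compound 2 to compound 3 (1.01 log units; beyond the scatter), and hydrogen in place of (3-phenylpropyl)sulfanyl gives an at least 9.9-fold higher number from compound 1 to compound 3 (0.99 log units; beyond the scatter). Compound 3 gives a limit of the assay and not a number: the limit of > 50000 nM in this assay, at which 1 of the 3 values shown sits. Going by these compounds alone, the earlier pair showed only that one group could replace another on the sulfur-bound chain, whereas this change removes the whole substituent.

As far as these compounds go, the true size of both steps remains open. Also open, from the compounds shown here alone, is whether the sulfur or the group it carries accounts for the difference, which a methylsulfanyl group or an amine at this position could help separate.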